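The compounds below may be only part of what the source reports. "The series", "measured", "known", "first", "only" and "open" are said of these compounds alone.

Compound 1 `COc1ccccc1Oc1c(N)nc(-c2ccccc2)nc1Cl`: "not active" (no number reported)
Compound 2 `COc1ccc(-c2nc(N)c(Oc3ccccc3OC)c(Cl)n2)cc1`: 8200 nM
Compound 3 `COc1ccccc1Oc1c(N)nc(-c2cccc(F)c2)nc1Cl`: 17000 nM

In a toxicity assay on HaCaT cells (Homo sapiens) for cytotoxicity, read by CCK-8 assay, with a stated time of 24 h (on this read-out lower numbers stand for higher toxicity in this test and higher numbers for lower toxicity in this test), compound 3 gives 17000 nM, the higher of the two numbers available. Compound 2 gives 8200 nM, while compound 1 is reported as "not active" (no number reported), without a number. Compound 4 `COc1ccccc1Oc1c(N)nc(-c2ccc(F)cc2)nc1Cl` carries 4-fluorophenyl in place of 3-fluorophenyl on an aromatic carbon. For the measured compounds named here, only one measured step bears on this: a 2.1-fold higher number from compound 2 to compound 3 (0.32 log units; beyond the scatter). It is modest, and it swaps a different group, so no direction can be taken from it. A small step in this assay is therefore expected, possibly none beyond the scatter. The expected step is a 1.2-fold lower number from compound 3 to compound 4 (0.08 log units; within the scatter). For compound 4 the estimated value is 14000 nM, within an expected range of 6000 nM to 35000 nM.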

Compound 4, half-maximal cytotoxic concentration: 42600 nM
Compound 4: middle estimate off by 3.0-fold (0.48 log units), on the low side; the whole stated range lies below it.
By their numbers in this assay, from the lowest: compound 2; then compound 3; then compound 4.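

Where the fluoro sits on the phenyl ring matters in this assay: the step of a 2.5-fold higher number from compound 3 to compound 4 (0.40 log units; beyond the scatter) changes only that placement, a comparison the earlier compounds could not offer. Fluoro in place of methoxy gives a 5.2-fold higher number from compound 2 to compound 4 (0.72 log units; beyond the scatter) and shows that 4-fluorophenyl also reads higher than 4-methoxyphenyl on this core. Nothing measured here explains either step.

Compound 1, with its plain phenyl, has no number, so neither fluorophenyl can be set against it. On these data alone, how an amine or a carboxylic acid on the phenyl ring would read remains open.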